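Trifluoromethyl for Fluoro on an Aryl Carbamate

The source may hold more compounds than are shown below. What is called first, only, known or untested is meant among the compounds shown, and "the series" means these compounds.

Measured compounds:
Compound 1 `O=C(Nc1ccccc1)Oc1ccc(Cl)cc1C(=O)Nc1ccc(F)cc1` gives 3250 nM in an ADME assay on HepG2 cells (Homo sapiens), read by MTT assay, with a stated time of 72 h, in the presence of a further agent that is not named here; a higher number here means a weaker inhibitor, a lower number a stronger inhibitor.
Compound 2 `O=C(NCc1ccccc1)Oc1ccc(Cl)cc1` is reported only as a limit in this assay, at > 125000 nM.

Among the measured compounds shown here, compound 1 holds the only definite number among the two values shown, since the other value is a limit, (the limit of > 125000 nM in this assay, at which 1 of the 2 values shown sits), rather than a measurement. For the measured compounds named here, the pair gives no measured step. Compound 2 lacks the amide-bearing arm of compound 1 and its value is a limit; what the two show is simply that compound 1 reads as an inhibitor where compound 2 does not.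

Compound 3 `O=C(Nc1ccccc1)Oc1ccc(Cl)cc1C(=O)Nc1ccc(C(F)(F)F)cc1` differs from compound 1 by trifluoromethyl in place of fluoro on an aromatic carbon. Going by the values given here, no measured step of this kind is available, so the size of the effect in this assay is uncertain. It is expected to be small, most likely within the scatter of repeated measurements, with perhaps a slight shift toward a stronger inhibitor. Compound 3 is therefore expected to give about 2500 nM in this assay, with a range from 800 nM to 8000 nM. This estimate means a step of a 1.3-fold lower number from compound 1 to compound 3 (0.11 log units; within the scatter) that is expected to stay near the scatter.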

Compound 3, half-maximal inhibitory concentration: 2450 nM
Compound 3: the middle estimate sits 1.0-fold (0.01 log units) above what was measured; the range from low to high includes it.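

Among the compounds shown here, replacing fluoro with trifluoromethyl on the aromatic carbon para to a large group gives a 1.3-fold lower number from compound 1 to compound 3 (0.12 log units; within the scatter) in this assay, the first measured step at this position. Among the compounds shown, this position therefore holds either group without the read-out leaving the scatter, so 4-fluorophenyl and 4-(trifluoromethyl)phenyl cannot be told apart here, and the inhibition seen for compound 1 is kept in compound 3. The data shown offer no measured property that would explain this outcome.

It remains open whether the same position would keep this reading with a group of another kind, such as an amine, a carboxylic acid or a longer chain, since both groups shown here are fluorinated and neither carries a hydrogen-bond donor or acceptor in the count given for this change. From the compounds shown here alone, it is also open which part of the amide-bearing arm matters for the reading, given that compound 2 differs from compound 1 in more than one place and so cannot be compared with it step by step.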